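Swapping chloro for methyl on a diaryl urea ester

The source may hold more compounds than are shown below. What is called first, only, known or untested is meant among the compounds shown, and "the series" means these compounds.

Three close relatives of one urea-linked core have been tested in a functional assay on HT-29 cells (Homo sapiens) for antiproliferative activity, read by MTT assay, with a stated time of 48 h; a lower number here means a stronger inhibitor, a higher number a weaker inhibitor. Compound 1 `O=C(Nc1ccc(OC(=O)c2ccccc2)cc1)Nc1ccc(Cl)c(C(F)(F)F)c1` gives 151000 nM. Compound 2 `Cc1ccc(C(=O)Oc2ccc(NC(=O)Nc3ccccc3)cc2)cc1` gives 19900 nM. Compound 3 `O=C(Nc1ccc(Cl)cc1)Nc1ccc(OC(=O)c2ccccc2)cc1` gives 56000 nM, which places it second highest of the three numbers, between compound 1 and compound 2. Within the data shown here, only one pair differs in a single place: a 2.7-fold lower number from compound 1 to compound 3 (0.43 log units; beyond the scatter). Compound 2 differs from compound 3 in two places at once, so its value can only be read on its own.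

Compound 4 `Cc1ccc(NC(=O)Nc2ccc(OC(=O)c3ccccc3)cc2)cc1` is the next member. Its difference from compound 3 is methyl in place of chloro on an aromatic carbon. Among the measured compounds shown here, no measured step covers this exact exchange, and the single step known concerns a different group, so there is no direct guide. The expectation is therefore a change in this assay that stays close to the scatter, worded as a 1.4-fold lower number from compound 3 to compound 4 (0.15 log units; within the scatter). Compound 4 is estimated at 40000 nM, with a range from 15000 nM to 120000 nM.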

Compound 4, half-maximal inhibitory concentration: 104000 nM
For compound 4 the middle estimate is 2.6-fold (0.41 log units) below the measured one; the measured number falls inside the stated range.
By their numbers in this assay, from the lowest: compound 2; then compounds 3, 4 and 1 (each within the scatter of the next, the first and the last beyond it).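

In this assay methyl in place of chloro, para to a large group, gives a 1.9-fold higher number from compound 3 to compound 4 (0.27 log units; within the scatter) and so does not separate the two groups at this position. This is the first step among the compounds shown that changes the group at this place itself, since the earlier step left the chloro in place and concerned trifluoromethyl; here, 4-chlorophenyl and 4-methylphenyl give values that cannot be told apart. No measurement at hand explains this result. 

One exchange of two single-atom-sized groups says little about how much this position tolerates in general. From the compounds shown here alone, whether a larger or very different group here, such as an amine, a carboxylic acid or a longer chain, would shift the number beyond the scatter remains open.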